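This account rests on a few compounds, and the source may have more. Where it says the series, first, only, none or still open, it means among the compounds named here.

In a functional assay on NRK-49F cells (Rattus norvegicus) for cytotoxicity, read by MTT assay, with a stated time of 24 h (a lower number here means a stronger inhibitor, a higher number a weaker inhibitor), compound 1 `COc1cc(/C=C(\C#N)C(=O)N/N=C(\C)c2c(O)c3ccc(O)cc3oc2=O)ccc1O` gives 55400 nM, compound 2 `COc1ccc(/C=C(\C#N)C(=O)N/N=C(\C)c2c(O)c3ccc(O)cc3oc2=O)cc1` gives 96100 nM and compound 3 `C/C(=N\NC(=O)/C(C#N)=C/c1ccc(N(C)C)cc1)c1c(O)c2ccc(O)cc2oc1=O` gives 53400 nM. Compound 3 thus stands within the scatter of both other compounds, and the numbers do not set it apart from either. The next compound, compound 4 `C/C(=N\NC(=O)/C(C#N)=C/c1cccc([N+](=O)[O-])c1)c1c(O)c2ccc(O)cc2oc1=O`, has 3-nitrophenyl in place of 4-(dimethylamino)phenyl on a double-bonded chain carbon bound to a double-bonded chain carbon. For the measured compounds named here, three measured steps bear on this change, as each alters the same part of the molecule. They are a 1.7-fold higher number from compound 1 to compound 2 (0.24 log units; within the scatter), a 1.0-fold lower number from compound 1 to compound 3 (0.02 log units; within the scatter) and a 1.8-fold lower number from compound 2 to compound 3 (0.26 log units; within the scatter). Going by the values given here, all three stay within the scatter, although no measured compound carries 3-nitrophenyl, so they guide the expectation only loosely. No shift beyond the scatter is therefore expected in this assay, and no direction is favoured with any confidence. The estimated change is a 1.1-fold higher number from compound 3 to compound 4 (0.05 log units; within the scatter). For compound 4 the expected value is 60000 nM, with an estimated range from 25000 nM to 130000 nM.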

Compound 4, half-maximal inhibitory concentration: 46500 nM
Estimate against measurement, compound 4: 1.3-fold (0.11 log units) above; the range from low to high includes it.
By their numbers in this assay, from the lowest: compounds 4, 3, 1 and 2 (each within the scatter of the next, the first and the last beyond it).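

In this assay, 3-nitrophenyl on a double-bonded chain carbon bound to a double-bonded chain carbon stays within the scatter of 4-(dimethylamino)phenyl (a 1.1-fold lower number from compound 3 to compound 4 (0.06 log units; within the scatter)) and of 4-hydroxy-3-methoxyphenyl (a 1.2-fold lower number from compound 1 to compound 4 (0.08 log units; within the scatter)). Against 4-methoxyphenyl, it gives the first step among these compounds to pass the scatter (a 2.1-fold lower number from compound 2 to compound 4 (0.32 log units; beyond the scatter)), so a change of aryl group at this position can now be seen to shift the number, though only modestly. Nothing measured here accounts for that step.

From the compounds shown here alone, all four compounds carry a substituted phenyl at this place, so it stays open how a longer alkyl chain or a carboxylic acid on the phenyl would read. For the compounds shown here, with 3-nitrophenyl as the only nitro compound, it also stays open whether 4-nitrophenyl would read the same.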